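Sulfamoyl for cyclohexyloxycarbonyl: metabolic stability in the series

This account rests on a few compounds, and the source may have more. Where it says the series, first, only, none or still open, it means among the compounds named here.

Of the compounds shown here, three carry a number so far. Compound 1 `COc1ccc(-c2c(C)nc3c(N4CC[C@@H](NC(C)=O)C4)cc(C)nn23)cn1` was run in an ADME assay on microsomes from liver (Homo sapiens) for metabolic stability, read by LC-MS, with NADPH named in the record, with a stated time of 60 min, tested at 1 uM, in the absence of a further agent; a lower number here means that less of the compound is left, a higher number that more of the compound is left; for compound 1 the record shows only the limit > 95%. Compound 2 `CC(=O)N[C@@H]1CCN(c2cc(C)nn3c(-c4ccc(OC(F)(F)F)cc4)c(C)nc23)C1` likewise returns only the limit > 95% in this assay. Compound 3 `COc1ccc(-c2c(C)nc3c(N4CC[C@@H](NC(=O)OC5CCCCC5)C4)cc(C)nn23)cc1OC` is no different: in this assay compound 3 gives the limit > 95%, a boundary of the assay rather than a number. So compound 3 stands at the top of what the assay reports, and the limit of > 95% in this assay, at which 3 of the 3 values shown sit, sums up the whole set. For the measured compounds named here, no pair of measured compounds differs in one place, so no step size is known from measurement.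

Compound 4 `COc1ccc(-c2c(C)nc3c(N4CC[C@@H](NS(N)(=O)=O)C4)cc(C)nn23)cc1OC` is the next candidate. It differs from compound 3 by sulfamoyl in place of cyclohexyloxycarbonyl on an amine nitrogen. With every measured value sitting at the limit, the step of a number at least 1 percentage points lower from compound 3 to compound 4 (that floor lies within the scatter) is expected to be none beyond the scatter, in either direction. For compound 4 the value in this assay is expected near 94%, between 80% and 99%, most probably again reported only as the limit.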

Compound 4, percent of the compound remaining: > 95%
Compound 4: only a limit was reported; the forecaster's own chance of this, stated with the estimate: 70%; middle value at least 1 percentage points away from the limit.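

Compound 3 and compound 4 both stand at a limit of the assay, so no step can be read between them: the limit of > 95% in this assay, at which 4 of the 4 values shown sit.

The compounds shown leave open which change on the shared core, if any, would give a readable number rather than a limit.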